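Methylating the phenol of a pyrazole urea: an expected shift

This account rests on a few compounds, and the source may have more. Where it says the series, first, only, none or still open, it means among the compounds named here.

Measured compounds:
- compound 1, `COc1cc(Cl)cc(-c2nn(-c3cccc(NC(=O)c4ccc(Cl)c(Cl)c4)c3)cc2-c2ccncc2)c1`, 71.6%
- compound 2, `O=C(Nc1cccc(-n2cc(-c3ccncc3)c(-c3cc(O)cc(Cl)c3)n2)c1)Nc1ccc(Cl)c(C(F)(F)F)c1`, 44.5%

In a functional assay on SNB-19 cells (Homo sapiens) for inhibition, read by sulforhodamine B assay, with a stated time of 48 h, tested at 10 uM (a lower number here means a stronger effect, a higher number a weaker effect of the compound at the concentration tested), compound 2 gives the lower of the two numbers, and compound 1 sits well above it, beyond the scatter. Compound 3, `COc1cc(Cl)cc(-c2nn(-c3cccc(NC(=O)Nc4ccc(Cl)c(C(F)(F)F)c4)c3)cc2-c2ccncc2)c1`, has not been measured. It differs from compound 2 in one place: methyl in place of hydrogen on an oxygen on an aromatic ring. Among the compounds with values here, no measured pair shows this change directly, so the step is uncertain; a move toward a higher number of modest size seems plausible, though it may stay within the scatter. The expected step is a number 11.5 percentage points higher from compound 2 to compound 3 (beyond the scatter). Compound 3 is estimated at 56%, ranging from 38% to 78%.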

Compound 3, a percentage reported as activity, at one concentration (the size of the read-out at that concentration, not a potency): 28.1%
Estimate against measurement, compound 3: 27.9 percentage points above; the whole stated range lies above it.
By their numbers in this assay, from the lowest: compound 3; then compound 2; then compound 1.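

In this assay, methyl in place of hydrogen on the oxygen of the aromatic ring strengthens the effect (a number 16.4 percentage points lower from compound 2 to compound 3 (beyond the scatter)), so the hydroxy hydrogen is not required for activity in this series. With the methoxy kept, (4-chloro-3-(trifluoromethyl)phenyl)amino in place of 3,4-dichlorophenyl on the carbonyl carbon gives a large gain (a number 43.5 percentage points lower from compound 1 to compound 3 (beyond the scatter)). Nothing available explains either step. As far as these compounds go, whether an ethoxy group or an amine at the same ring position would give a still lower number remains open. A reading at a single concentration shows only whether the effect is stronger or weaker at that concentration.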